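The compounds below may be only part of what the source reports. "The series", "measured", "known", "first", "only" and "open" are said of these compounds alone.

Compound 3 `CN1[C@@H]2c3[nH]c4ccccc4c3C[C@H]1[C@H](C#N)N1[C@@H](CNC(=O)c3ccc(F)cc3)c3[nH]c4ccccc4c3C[C@@H]21` gives 310 nM in a functional assay on BGC-823 cells (Homo sapiens) for cytotoxicity, read by MTT assay, with a stated time of 72 h (on this read-out lower numbers stand for stronger inhibition and higher numbers for weaker inhibition), the second highest of the three numbers: compound 1 `CN1[C@@H]2c3[nH]c4ccccc4c3C[C@H]1[C@H](C#N)N1[C@@H](CNC(=O)c3cccc(C(F)(F)F)c3)c3[nH]c4ccccc4c3C[C@@H]21` gives 870 nM and compound 2 `CN1[C@@H]2c3[nH]c4ccccc4c3C[C@H]1[C@H](C#N)N1[C@@H](CNC(=O)c3ccc(Cl)cc3)c3[nH]c4ccccc4c3C[C@@H]21` gives 110 nM. Compound 4 `CCc1ccc(C(=O)NC[C@H]2c3[nH]c4ccccc4c3C[C@H]3[C@H]4c5[nH]c6ccccc6c5C[C@@H]([C@H](C#N)N23)N4C)cc1` differs from compound 3 by ethyl in place of fluoro on an aromatic carbon. Among the measured compounds shown here, no measured step swaps a halogen for an alkyl, but the steps that bear on this aromatic carbon are a 2.8-fold lower number from compound 1 to compound 3 (0.45 log units; beyond the scatter) and a 7.9-fold lower number from compound 1 to compound 2 (0.90 log units; beyond the scatter), and the direct comparison a 2.8-fold higher number from compound 2 to compound 3 (0.45 log units; beyond the scatter) shows chloro giving the lower number than fluoro at that carbon. For compound 4 a modest step toward a lower number is therefore expected, a 1.9-fold lower number from compound 3 to compound 4 (0.29 log units; within the scatter), with wide uncertainty since no alkyl has been measured here. Compound 4 is estimated at 160 nM, within a range from 50 nM to 500 nM.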

Compound 4, half-maximal inhibitory concentration: 660 nM
Estimate against measurement, compound 4: 4.1-fold (0.62 log units) below, outside the stated range (above it).
By their numbers in this assay, from the lowest: compound 2; then compound 3; then compounds 4 and 1 (each within the scatter of the next).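

In this assay, ethyl on the aromatic carbon para to a large group gives a higher number than either halogen tried there (a 2.1-fold higher number from compound 3 to compound 4 (0.33 log units; beyond the scatter); a 6.0-fold higher number from compound 2 to compound 4 (0.78 log units; beyond the scatter)), so the first non-halogen group does not extend the gain seen with chloro. The 4-ethylphenyl amide also stays within the scatter of the 3-(trifluoromethyl)phenyl amide (a 1.3-fold lower number from compound 1 to compound 4 (0.12 log units; within the scatter)). Nothing available gives a reason for these steps.

Still open, on these data alone, is whether bromo or methoxy on this carbon tracks chloro or ethyl. Also open, as far as these compounds go, is whether a longer chain or an amine there raises the number further.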